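From 3-fluorophenyl to 1H-indazol-6-yl in compound 4

This account rests on a few compounds, and the source may have more. Where it says the series, first, only, none or still open, it means among the compounds named here.

Measured in a functional assay on A-375 cells (Homo sapiens) for antiproliferative activity; on this read-out lower numbers stand for stronger inhibition and higher numbers for weaker inhibition:
- compound 1 `O=C(Nc1ccc(-c2cscn2)cc1)[C@H]1CCCN(Cc2ccc(F)c(F)c2)C1`: 190 nM
- compound 2 `O=C(Nc1ccc(-c2cscn2)cc1)C1CCCN(Cc2cccc(F)c2)C1`: 2450 nM
- compound 3 `O=C(Nc1ccc(-c2cscn2)cc1)C1CCCN(Cc2cccc(OC(F)(F)F)c2)C1`: > 20000 nM, a limit of the assay

Compound 2 holds the higher of the two exact numbers, and compound 1 lies well below it. Compound 4 `O=C(Nc1ccc(-c2cscn2)cc1)C1CCCN(Cc2ccc3cn[nH]c3c2)C1` carries 1H-indazol-6-yl in place of 3-fluorophenyl on a saturated chain carbon bound to an amine nitrogen in a ring. For the measured compounds named here, the one measured step that changes only this group is an at least 8.1-fold higher number from compound 2 to compound 3 (0.91 log units; beyond the scatter). That step runs upward, yet compound 1 at 190 nM shows that a change in this group can also come with a lower number. The direction is therefore open, and no step beyond the scatter is the expected outcome in this assay. The expected change is a 1.2-fold higher number from compound 2 to compound 4 (0.09 log units; within the scatter). For compound 4 the estimated value is 3000 nM, with an expected range from 500 nM to 15000 nM.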

Compound 4, half-maximal inhibitory concentration: > 20000 nM
Compound 4: a limit, no number (the forecaster's own chance of this, stated with the estimate: 20%); middle value at least 6.6-fold (0.82 log units) away from the limit.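

In this assay, the change to 1H-indazol-6-yl gives an at least 8.1-fold higher number from compound 2 to compound 4 (0.91 log units; beyond the scatter), so a replacement of the whole 3-fluorophenyl group, and not only of its fluoro, also moves the number upward. Compound 1, at 190 nM, goes against that upward direction among changes in this group. The value of compound 4 is a limit and not a number, so the full size of the step cannot be read: the limit of > 20000 nM in this assay, at which 2 of the 4 values shown sit.

From the compounds shown here alone, it remains open whether a chloro or a methyl group in place of fluoro on the phenyl ring would stay close to compound 2. Going by these compounds, it also remains open whether a simple phenyl or a pyridinyl group in place of 3-fluorophenyl would do so.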